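The source may report more compounds than this note shows. Statements on the series, on what has been measured and on what is new or still open speak of the compounds shown alone.

Measured compounds:
- compound 1, `COc1cccc(CNCCCNc2ccnc3cc(Oc4ccc(Cl)cc4)ccc23)c1O`, a physicochemical assay for solubility, with a stated time of 18 h, at pH 7.4; a lower number here means a less soluble compound, a higher number a more soluble compound: 14500 nM
- compound 2, `Fc1ccc(-c2ccc3c(NCCCNCc4ccco4)ccnc3c2)cc1`, this assay: 32000 nM
- compound 3, `COc1ccc(F)cc1CNCCCNc1ccnc2cc(Oc3ccc(C(C)(C)C)cc3)ccc12`, this assay: 14500 nM

Compound 1 stands level with compound 3 at the digits shown, and the two together give the lowest numbers of the three; compound 2 gives a higher number, and that gap lies beyond the scatter. Compound 2 differs from compound 1 in several places at once, so its higher number cannot be tied to any single change.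

The next compound is compound 4, `COc1cccc(CNCCCNc2ccnc3cc(-c4ccccc4)ccc23)c1O`, not yet measured in this assay. Its difference from compound 1: phenyl in place of 4-chlorophenoxy on an aromatic carbon. Compound 2 also carries an aromatic ring joined directly to the shared core rather than through an oxygen, and it shows the higher number, but no single-change comparison exists to support a direction. The expected step from compound 1 to compound 4 is a small rise, a 1.5-fold higher number from compound 1 to compound 4 (0.18 log units; within the scatter), of a size that sits near the edge of the scatter. The estimate for compound 4 is 22000 nM, with a range from 9000 nM to 50000 nM.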

Compound 4, solubility: 32000 nM
The estimate for compound 4 lay 1.5-fold (0.16 log units) below the measured number; measured number inside the range.
By their numbers in this assay, from the lowest: compounds 1 and 3 (each within the scatter of the next); then compounds 2 and 4 (each within the scatter of the next).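

In this assay, among these compounds, phenyl in place of 4-chlorophenoxy on this aromatic carbon gives a 2.2-fold higher number from compound 1 to compound 4 (0.34 log units; beyond the scatter), the first single-change step, and it shows that the group at this position can move the number beyond the scatter. The step is modest, and the linking oxygen and the chlorine leave together, so it cannot be assigned to either one. Nothing measured here explains the step.

Unsubstituted phenoxy and 4-chlorophenyl at this aromatic carbon would separate the loss of the oxygen from the loss of the chlorine, so that question stays open. Also open, on these data alone, is how an amine or a carboxylic acid at the same carbon would read in this assay, and whether the step holds when the benzylic group on the side chain changes.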